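A few compounds are considered here, and "the series" means these few. Any claim that something is new, unique, unknown or untested is made for them only; others in the source may bear on it.

Measured compounds:
compound 1 `COc1ccc2c(=O)c(/C=C/C(=O)NCc3ccccc3F)coc2c1` — 8450 nM
compound 2 `COc1ccc2c(=O)c(/C=C/C(=O)NCc3ccc(C)cc3)coc2c1` — 14300 nM

For the measured compounds named here, in a functional assay on Huh-7 cells (Homo sapiens) for inhibition, read by MTT assay, with a stated time of 48 h (a higher number here means a weaker inhibitor, a lower number a stronger inhibitor), compound 2 sits within the scatter of compound 1, the only other measured compound; the step of a 1.7-fold higher number from compound 1 to compound 2 (0.23 log units; within the scatter) tells no real difference between them. Compound 3 `CCOc1ccc(NC(=O)/C=C/c2coc3cc(OC)ccc3c2=O)cc1` differs from compound 2 by 4-ethoxyphenyl in place of 4-methylbenzyl on an amide-type nitrogen. Going by the values given here, the single measured step concerns an exchange of the ring on the saturated chain carbon, not the loss of that carbon, so it bears on the new change only loosely, and it was itself within the scatter. No shift beyond the scatter is therefore expected in this assay. Compound 3 is estimated at 12000 nM, in a range from 4000 nM to 36000 nM, which means an expected step of a 1.2-fold lower number from compound 2 to compound 3 (0.08 log units; within the scatter).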

Compound 3, half-maximal inhibitory concentration: 3230 nM
The estimate for compound 3 lay 3.7-fold (0.57 log units) above the measured number; the whole stated range lies above it.
By their numbers in this assay, from the lowest: compound 3; then compounds 1 and 2 (each within the scatter of the next).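

In this assay, the group on the amide-type nitrogen now makes a difference beyond the scatter: 4-ethoxyphenyl in place of 4-methylbenzyl gives a 4.4-fold lower number from compound 2 to compound 3 (0.65 log units; beyond the scatter), and 4-ethoxyphenyl in place of 2-fluorobenzyl gives a 2.6-fold lower number from compound 1 to compound 3 (0.42 log units; beyond the scatter), both modest steps. The earlier exchange between the two benzyl groups had shown no such separation. Nothing measured here explains the shift.

The change removes the saturated chain carbon and brings in the ethoxy group at once, and the compounds shown do not separate the two. From the compounds shown here alone, how a plain phenyl, a 4-methoxyphenyl or a 4-ethoxybenzyl would read on this nitrogen remains open.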